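The compounds below may be only part of what the source reports. "The series", "measured", "known", "first", "only" and "open" are said of these compounds alone.

Compound 3 `COc1ccc(-c2nn(-c3ccccc3)cc2/C=C/C(=O)c2ccc3c(c2OCc2ccccc2)CC(C)(C)O3)cc1` gives 18400 nM in a functional assay on PC-3 cells (Homo sapiens) for antiproliferative activity, read by MTT assay, with a stated time of 48 h (a lower number here means a stronger inhibitor, a higher number a weaker inhibitor), and compound 2 `CC1(C)Cc2c(ccc(C(=O)/C=C/c3cn(-c4ccccc4)nc3-c3ccc(Cl)cc3)c2OCc2ccccc2)O1` gives 26000 nM in this assay, the two sitting within the scatter of each other, as the step of a 1.4-fold lower number from compound 2 to compound 3 (0.15 log units; within the scatter) shows. Compound 1 `CC1(C)Cc2c(ccc(C(=O)/C=C/c3cn(-c4ccccc4)nc3-c3cccc([N+](=O)[O-])c3)c2OCc2ccccc2)O1` gives only a limit in this assay, > 100000 nM. Measured from compound 1, the steps were an at least 3.8-fold lower number from compound 1 to compound 2 (0.58 log units; beyond the scatter) and an at least 5.4-fold lower number from compound 1 to compound 3 (0.73 log units; beyond the scatter). Compound 4 `Cc1ccc(-c2nn(-c3ccccc3)cc2/C=C/C(=O)c2ccc3c(c2OCc2ccccc2)CC(C)(C)O3)cc1` differs from compound 3 by methyl in place of methoxy on an aromatic carbon. Of the measured steps, only the exchange of chloro for methoxy touches the same group, and it stayed within the scatter; the two steps away from 3-nitrophenyl concern another substituent. Compound 4 is therefore expected to show no step beyond the scatter, a 1.1-fold higher number from compound 3 to compound 4 (0.04 log units; within the scatter). The estimate for compound 4 is 20000 nM, between 8000 nM and 50000 nM.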

Compound 4, half-maximal inhibitory concentration: 24200 nM
For compound 4 the middle estimate is 1.2-fold (0.08 log units) below the measured one; the measured number falls inside the stated range.
By their numbers in this assay, from the lowest: compounds 3, 4 and 2 (each within the scatter of the next). At a limit, above all of these: compound 1.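

On this aromatic carbon, para to a large group, methyl joins methoxy and chloro with no separation in this assay: a 1.3-fold higher number from compound 3 to compound 4 (0.12 log units; within the scatter), and a 1.1-fold lower number from compound 2 to compound 4 (0.03 log units; within the scatter). The third substituent in this set thus sits apart from 3-nitrophenyl, with an at least 4.1-fold lower number from compound 1 to compound 4 (0.61 log units; beyond the scatter). That step rests on a limit for compound 1, not on a number: the limit of > 100000 nM in this assay, at which 1 of the 4 values shown sits.

The compounds shown leave open whether an amine or a carboxylic acid on this carbon would give a step beyond the scatter. They also leave open whether 4-nitrophenyl would behave like 3-nitrophenyl or like the other three groups.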